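A few compounds are considered here, and "the series" means these few. Any claim that something is new, unique, unknown or untested is made for them only; others in the source may bear on it.

Compound 1 `COc1ccc2c(c1)NC(=O)CN2c1nc(NCCCO)nc2ccccc12` is the starting point. For the measured compounds named here, in a functional assay on A549 cells (Homo sapiens) for inhibition, read by sulforhodamine B assay, with a stated time of 48 h (on this read-out higher numbers stand for weaker inhibition of growth and lower numbers for stronger inhibition of growth), compound 1 gives 5.18 nM, which is the low end of the three numbers known. Compound 3 `COc1ccc2c(c1)NC(=O)CN2c1nc(Nc2ccc(C#N)cc2)nc2ccccc12` gives 6.17 nM, and the step of a 1.2-fold higher number from compound 1 to compound 3 (0.08 log units; within the scatter) stays within the usual scatter. Compound 2 `COc1ccc2c(c1)NC(=O)CN2c1nc(Nc2cccc(C#N)c2)nc2ccccc12` gives 75.4 nM; the step of a 15-fold higher number from compound 1 to compound 2 (1.16 log units; beyond the scatter) is large, as is the step of a 12-fold lower number from compound 2 to compound 3 (1.09 log units; beyond the scatter). Compound 4 `COc1ccc2c(c1)NC(=O)CN2c1nc(NC2CC2)nc2ccccc12` differs from compound 1 in one place: cyclopropyl in place of 3-hydroxypropyl on a nitrogen on an aromatic ring. Going by the values given here, no measured step swaps the 3-hydroxypropyl group for a small non-aromatic ring, so the two steps from compound 1 only show that replacing it can leave the number unchanged or raise it sharply. A modest rise is therefore expected, a 2.3-fold higher number from compound 1 to compound 4 (0.36 log units; beyond the scatter). Compound 4 is estimated at 12 nM, within 4 nM to 40 nM.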

Compound 4, concentration for 50% growth inhibition in the A549 assay: 1.12 nM
The estimate for compound 4 lay 11-fold (1.03 log units) above the measured number; measured number below the stated range.
By their numbers in the A549 assay, from the lowest: compound 4; then compounds 1 and 3 (each within the scatter of the next); then compound 2.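

In the A549 assay a small non-aromatic ring on this nitrogen goes below every earlier number, and compound 4 is the strongest of the four: (a 4.6-fold lower number from compound 1 to compound 4 (0.67 log units; beyond the scatter)), (a 5.5-fold lower number from compound 3 to compound 4 (0.74 log units; beyond the scatter)) and (a 67-fold lower number from compound 2 to compound 4 (1.83 log units; beyond the scatter)). In a physicochemical assay for solubility, read by HPLC, at pH 7.4 (a higher number here means a more soluble compound, a lower number a less soluble compound), compound 1 gives 80.9 ug/mL and compound 4 gives 67.8 ug/mL, with (a 1.2-fold lower number from compound 1 to compound 4 (0.08 log units; within the scatter)). Nothing measured here gives a cause for the drop in growth-inhibition concentration.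

Still open, on these data alone, is whether a larger ring such as cyclobutyl or cyclohexyl, or a chain ending in an amine, would keep the number this low.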